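This account rests on a few compounds, and the source may have more. Where it says the series, first, only, none or still open, it means among the compounds named here.

Measured compounds:
- compound 1 `COc1cc(C(=O)NNC(=S)Nc2csc(-c3ccccc3)c2)cc(OC)c1OC` — 32000 nM
- compound 2 `COc1cc(C(=O)NNC(=S)Nc2csc(-c3ccc(C)cc3)c2)cc(OC)c1OC` — 13000 nM
- compound 3 `O=C(NNC(=S)Nc1csc(-c2ccccc2)c1)c1ccc(O)cc1` — 40000 nM

In a functional assay on B16-F10 cells (Mus musculus) for inhibition, read by colorimetric assay and MTT assay, with a stated time of 72 h (a lower number here means a stronger inhibitor, a higher number a weaker inhibitor), compound 2 holds the lowest of the three numbers. Among the measured compounds shown here, the step of a 2.5-fold lower number from compound 1 to compound 2 (0.39 log units; beyond the scatter) is the only single-point change measured. Relative to compound 1, compound 3 carries a different aryl amide and gives 40000 nM; the two differ in more than one place, so nothing further follows.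

Compound 4 `COc1cc(OC)cc(C(=O)NNC(=S)Nc2csc(-c3ccc(C)cc3)c2)c1` is the next case. Relative to compound 2 the change is hydrogen in place of methoxy on an aromatic carbon. For the measured compounds named here, no measured step touches this position, so the direction is open; a small weakening, at most modest, is expected, consistent with a 1.5-fold higher number from compound 2 to compound 4 (0.19 log units; within the scatter). For compound 4 the expected value in this assay is 20000 nM, with a range from 8000 nM to 50000 nM.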

Compound 4, half-maximal inhibitory concentration: 13000 nM
Compound 4: middle estimate off by 1.5-fold (0.19 log units), on the high side; the range from low to high includes it.
By their numbers in this assay, from the lowest: compounds 2 and 4 (each within the scatter of the next); then compounds 1 and 3 (each within the scatter of the next).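

Within this assay hydrogen in place of methoxy on this aromatic carbon gives no change at the digits printed from compound 2 to compound 4 (within the scatter) and so shows, as the earlier compounds could not, that the methoxy para to a large group can be removed without a measurable loss. No measured evidence explaining this tolerance is available. On these data alone, whether this carbon also accepts an amine, a carboxylic acid or a longer chain remains open. Also open, as far as these compounds go, is whether removing either methoxy group ortho to this carbon would leave the number equally unchanged.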